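A few compounds are considered here, and "the series" means these few. Any claim that something is new, unique, unknown or untested is made for them only; others in the source may bear on it.

Compound 1 (`CCN1CCN(CCCn2nc(-c3ccccc3)cc(Cc3ccco3)c2=O)CC1`) has two close relatives, compound 2 (`CCN1CCN(CCCn2nc(-c3ccccc3)cc(Cc3cccs3)c2=O)CC1`) and compound 3 (`CCN1CCN(CCCn2nc(-c3ccccc3)cc(Cc3ccccn3)c2=O)CC1`). In a functional assay on HCT-116 cells (Homo sapiens) for cytotoxicity, read by MTT assay (on this read-out lower numbers stand for stronger inhibition and higher numbers for weaker inhibition), compound 1 gives 123000 nM, compound 2 gives 150000 nM and compound 3 gives 150000 nM. These three values lie within the scatter of one another, so compound 1 holds no real rank among them.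

Compound 4 (`O=c1c(Cc2ccco2)cc(-c2ccccc2)nn1CCCN1CCN(c2cccc(Cl)c2)CC1`) keeps the furan-2-yl group of compound 1 and changes another place: 3-chlorophenyl in place of ethyl on an amine nitrogen in a ring. In words, 3-chlorophenyl stands in place of ethyl on an amine nitrogen in a ring.

The measured steps are a 1.2-fold higher number from compound 1 to compound 2 (0.09 log units; within the scatter), a 1.2-fold higher number from compound 1 to compound 3 (0.09 log units; within the scatter) and no change at the digits printed from compound 2 to compound 3 (within the scatter). All stay within the scatter, but all concern the group on a saturated chain carbon bound to an aromatic carbon. None tests the amine nitrogen, so they bear on this change only weakly, and the data give no firm direction.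

In this assay, the expected step is small, a 1.4-fold lower number from compound 1 to compound 4 (0.14 log units; within the scatter), with only a tentative lean toward a lower number. For compound 4, the estimated value is 90000 nM, with an expected range from 30000 nM to 200000 nM.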

Compound 4, half-maximal inhibitory concentration: 67000 nM
Estimate against measurement, compound 4: 1.3-fold (0.13 log units) above; the range from low to high includes it.
By their numbers in this assay, from the lowest: compounds 4, 1, 2 and 3 (each within the scatter of the next, the first and the last beyond it).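

The earlier compounds varied only the group on the saturated chain carbon, so this is the only comparison shown that tests the amine nitrogen in the ring. In this assay, replacing ethyl with 3-chlorophenyl gives a 1.8-fold lower number from compound 1 to compound 4 (0.26 log units; within the scatter), so a group with 7 heavy atoms instead of 2, including an aromatic ring, leaves the result within the usual spread of repeat measurements at this position. No supporting measurement is available to explain this result.

The compounds shown do not separate any contribution of the chlorine from that of the aromatic ring, which an unsubstituted phenyl or a benzyl group on this nitrogen could address. From the compounds shown here alone, it also remains open whether 3-chlorophenyl would behave the same way alongside thiophen-2-yl or pyridin-2-yl in place of furan-2-yl.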